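This account rests on a few compounds, and the source may have more. Where it says the series, first, only, none or still open, it means among the compounds named here.

Three compounds share a fused two-ring core carrying a chloro group and a benzyl arm bearing a chloromethyl group. Compound 1 `ClCc1ccc(Cn2cnc3c(Cl)ncnc32)cc1` gives 1770 nM in a functional assay on MDA-MB-231 cells (Homo sapiens) for cytotoxicity, read by sulforhodamine B assay, with a stated time of 48 h; on this read-out higher numbers stand for weaker inhibition of growth and lower numbers for stronger inhibition of growth. Compound 2 `ClCc1cccc(Cn2cnc3c(Cl)ncnc32)c1` gives 1990 nM in this assay, the highest of the three numbers, though compound 1 lies within the scatter of it. Compound 3 `ClCc1ccc(Cn2cnc3nc(Cl)nc(Cl)c32)cc1` gives 1620 nM in this assay, again within the scatter of compound 2, so no ordering among the three can be claimed.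

Compound 4 `ClCc1cccc(Cn2cnc3c(Cl)nc(Cl)nc32)c1` has not been measured. It differs from compound 2 by chloro in place of hydrogen on an aromatic carbon. Going by the values given here, no measured pair shows this exact step, and nothing in the data suggests that any of the three measured compounds separates from the others beyond the scatter. The step from compound 2 to compound 4 is therefore expected to be small, a 1.1-fold lower number from compound 2 to compound 4 (0.04 log units; within the scatter), with no clear direction. In this assay compound 4 is expected to give about 1800 nM, with a range from 900 nM to 3600 nM.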

Compound 4, concentration for 50% growth inhibition: 1950 nM
Compound 4: middle estimate off by 1.1-fold (0.03 log units), on the low side; measured number inside the range.
By their numbers in this assay, from the lowest: compounds 3, 1, 4 and 2 (each within the scatter of the next).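

Chloro in place of hydrogen on the aromatic carbon between two ring nitrogen atoms gives a 1.0-fold lower number from compound 2 to compound 4 (0.01 log units; within the scatter) in this assay. Going by these compounds alone, this is the first direct reading at this position, and it shows that, on the arm of compound 2, this single added chlorine produces no difference that can be told from the scatter. No other measurement here bears on why the step is so small.

Going by these compounds, whether an amine, a methoxy group or a longer chain on this same carbon would separate from the hydrogen of compound 2 beyond the scatter remains open. On these data alone, it is also open whether the chloro step would read the same with the arm of compound 1.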